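The source may report more compounds than this note shows. Statements on the series, on what has been measured and on what is new or still open speak of the compounds shown alone.

Compound 1 `O=c1cc(CSC(=S)N2CCCC2)oc2ccccc12` — in a functional assay on LM7 cells (Homo sapiens) for antiproliferative activity, read by MTT assay, with a stated time of 72 h (a higher number here means a weaker inhibitor, a lower number a stronger inhibitor), compound 1 gives 40000 nM.
Compound 2 `O=c1cc(CSC(=S)N2CCCC2)oc2cc(Cl)ccc12` — in this assay compound 2 gives > 25000 nM, which is a limit of the assay and not a number.

Compound 1 carries the only number shown in this assay; the one other value is a limit. Among the measured compounds shown here, the step that the limit leaves unreadable from compound 1 to compound 2 cannot be read, since it runs into (the limit of > 25000 nM in this assay, at which 1 of the 2 values shown sits), so the single measured comparison tells nothing about size or direction.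

Compound 3 `CC(C)N(C(=S)SCc1cc(=O)c2ccccc2o1)C(C)C` differs from compound 1 at the thiocarbonyl carbon: diisopropylamino in place of pyrrolidin-1-yl on a thiocarbonyl carbon. For the measured compounds named here, no measured step touches this part of the molecule; the only measured step concerns the aromatic ring, and it is unreadable. With no comparison to lean on, the step from compound 1 to compound 3 is expected to stay within the scatter, which is what no change at the digits printed from compound 1 to compound 3 (within the scatter) means. Compound 3 is therefore expected near the value of compound 1 in this assay, at an estimated 40000 nM, with a range from 15000 nM to 120000 nM.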

Compound 3, half-maximal inhibitory concentration: > 25000 nM
Compound 3 was reported as a limit (the forecaster's own chance of this, stated with the estimate: 50%); the middle value lies beyond the limit too.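

In this assay compound 3 gives > 25000 nM, which is a limit of the assay and not a number, so its step from compound 1 cannot be read, any more than that of compound 2: the limit of > 25000 nM in this assay, at which 2 of the 3 values shown sit.

The compounds shown leave open whether either the chloro or the diisopropylamino change shifts antiproliferative activity from that of compound 1, and in which direction.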